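Replacing a hydroxylated chain with an oxane ring at the ester

A few compounds are considered here, and "the series" means these few. Any claim that something is new, unique, unknown or untested is made for them only; others in the source may bear on it.

Measured compounds:
compound 1 `CCCCC(O)CC(=O)O[C@H](CC=C(C)C)C1=CC(=O)c2c(O)ccc(O)c2C1=O` gives 45300 nM in a functional assay on DU-145 cells (Homo sapiens) for cytotoxicity, read by MTT assay; on this read-out higher numbers stand for weaker inhibition and lower numbers for stronger inhibition
compound 2 `CC(C)=CC[C@@H](OC(=O)c1ccoc1)C1=CC(=O)c2c(O)ccc(O)c2C1=O` reaches only the assay limit of > 100000 nM
compound 3 `CC[C@](C)(O)CC(=O)O[C@H](CC=C(C)C)C1=CC(=O)c2c(O)ccc(O)c2C1=O` gives 20500 nM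

Of the two numbers available, compound 3 stands lowest, with compound 1 nearest: a 2.2-fold lower number from compound 1 to compound 3 (0.34 log units; beyond the scatter). Compound 2 sits at a limit, (the limit of > 100000 nM in this assay, at which 1 of the 3 values shown sits), and is not a number. Compound 4 `CC(C)=CC[C@@H](OC(=O)C1CCCOC1)C1=CC(=O)c2c(O)ccc(O)c2C1=O` differs from compound 3 by one change: oxan-3-yl in place of 2-hydroxy-2-methylbutyl on a carbonyl carbon.

Among the measured compounds shown here, two measured steps bear on this change, both swapping a hydroxyl-bearing open chain for a ring on the carbonyl carbon. One is an at least 2.2-fold higher number from compound 1 to compound 2 (0.34 log units; beyond the scatter). The other runs the opposite way: an at least 4.8-fold lower number from compound 2 to compound 3 (0.68 log units; beyond the scatter). Both point the same direction: the ring gave the higher number. The oxan-3-yl group of compound 4 is a saturated ring rather than the aromatic furan-3-yl of compound 2, so the size of the step is uncertain. A rise beyond the scatter is expected for compound 4: a 2.4-fold higher number from compound 3 to compound 4 (0.39 log units; beyond the scatter). Compound 4 is estimated at 50000 nM, within 18000 nM to 140000 nM.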

Compound 4, half-maximal inhibitory concentration: 29700 nM
Estimate against measurement, compound 4: 1.7-fold (0.23 log units) above; measured number inside the range.
By their numbers in this assay, from the lowest: compounds 3, 4 and 1 (each within the scatter of the next, the first and the last beyond it). At a limit, above all of these: compound 2.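

In this assay, the oxan-3-yl ring stands at this carbonyl carbon without a step beyond the scatter from either hydroxylated chain: there is a 1.4-fold higher number from compound 3 to compound 4 (0.16 log units; within the scatter) and a 1.5-fold lower number from compound 1 to compound 4 (0.18 log units; within the scatter) even though, from compound 3 to compound 4, the single hydrogen-bond donor of the group is lost. The ring by itself therefore does not go with a high number, as an at least 3.3-fold lower number from compound 2 to compound 4 (0.52 log units; beyond the scatter) separates the saturated oxan-3-yl from the aromatic furan-3-yl at the same place. Compound 2 remains at a limit and not a number: the limit of > 100000 nM in this assay, at which 1 of the 4 values shown sits.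

The compounds shown leave open whether a piperidin-3-yl ring, with an amine nitrogen in place of the ring oxygen, would read like compound 4 in this assay. The same holds for an oxan-4-yl group.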